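The compounds below may be only part of what the source reports. "The series", "measured", "known", "first", "only" and "open" are said of these compounds alone.

Working notes on the series. Of the compounds shown here, two have been measured so far, compound 1 `COc1ccc(-c2cc(-c3ccc(F)cc3)nc(NC(=O)N/N=C\c3cccc(Cl)c3)n2)cc1OC` and compound 2 `C/C(=N/NC(=O)Nc1nc(-c2ccc(C)cc2)cc(-c2ccc(F)cc2)n1)c1ccc([N+](=O)[O-])cc1`, which share the same core and differ in the side group attached through the urea and in the substituent pattern of the aromatic rings. In a functional assay on the whole organism (strain Albino) with Mus musculus as the target, with a stated time of 4 h (on this read-out higher numbers stand for an effect only at larger amounts of compound and lower numbers for an effect already at smaller amounts), compound 1 gives 300 mg/kg. In this assay, among the measured compounds shown here, compound 2 gives 300 mg/kg, level with compound 1 at the digits recorded; the two values lie within the scatter of each other, so nothing can be said about an order between them, and no single-point step between the two is available.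

Compound 3 `C/C(=N/NC(=O)Nc1nc(-c2ccc(C)cc2)cc(-c2ccc(F)cc2)n1)c1ccc(Cl)cc1` has not yet been measured in this assay. It differs from compound 2 in one place only: chloro in place of nitro on an aromatic carbon. For the measured compounds named here, no measured pair in this set shows what this exchange does, so the expectation rests on compound 2 alone.

The step from compound 2 to compound 3 in this assay is expected to be none beyond the scatter, no change at the digits printed from compound 2 to compound 3 (within the scatter). For compound 3 in this assay the estimated value is 300 mg/kg, expected to fall between 150 mg/kg and 600 mg/kg.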

Compound 3, dose for half-maximal effect: 100 mg/kg
For compound 3 the middle estimate is 3.0-fold (0.48 log units) above the measured one; the whole stated range lies above it.
By their numbers in this assay, from the lowest: compound 3; then compounds 1 and 2 (each within the scatter of the next).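

In this assay, chloro in place of nitro on an aromatic carbon, para to a large group, gives a 3.0-fold lower number from compound 2 to compound 3 (0.48 log units; beyond the scatter). Among the compounds shown here, this is the first exchange that can be read at a single place, and it shows that this position is not indifferent to the read-out: going from 4-nitrophenyl to 4-chlorophenyl, with the rest of the structure unchanged, brings the effect to a smaller dose, though the step is modest. No measurement at hand bears on what lies behind this step.

As far as these compounds go, a single pair cannot separate what the departing nitro contributes from what the entering chloro contributes, so it remains open whether the dose would hold, rise or fall further with a bare hydrogen, an amine or a carboxylic acid at the same place. For the compounds shown here, it is also open whether the same exchange would give a similar step on another background, such as one carrying the side group and ring substituents of compound 1, since the series so far holds this change in one setting only.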